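A few compounds are considered here, and "the series" means these few. Any claim that something is new, unique, unknown or untested is made for them only; others in the source may bear on it.

Compound 2 `O=C(O)c1ccnc(N/N=C/c2ccccc2O)n1` gives 88% in an assay on isolated protein for inhibition of lysine-specific demethylase 5A (Homo sapiens), read by AlphaLISA, with stated times of 15 min and 1 h, tested at 10 uM (on this read-out higher numbers stand for more inhibition at the one concentration tested (going by the name of the read-out) and lower numbers for less inhibition), the higher of the two numbers measured: compound 1 `Oc1ccccc1/C=N/Nc1ncccn1` gives 32%, and the step of a number 56 percentage points higher from compound 1 to compound 2 (beyond the scatter) is the only one measured. Compound 3 `O=C(O)c1ccnc(N/N=C/c2ccccc2)n1` differs from compound 2 by hydrogen in place of hydroxy on an aromatic carbon. Going by the values given here, the one measured step concerns a different group and so does not bear on this change; nothing measured tells the effect of removing the hydroxy. Compound 3 is therefore estimated with a wide range, at 55%, between 20% and 85%, a step of a number 33 percentage points lower from compound 2 to compound 3 (beyond the scatter) expected toward less inhibition.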

Compound 3, a percentage reported as inhibition, at one concentration (the size of the read-out at that concentration, not a potency): 0%
Estimate against measurement, compound 3: 55 percentage points above; the measured number lies below the stated range.
By their numbers in this assay, from the lowest: compound 3; then compound 1; then compound 2.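

In this assay, the hydroxy on the aromatic ring of carbon only, ortho to a large group, proves indispensable among these compounds: hydrogen in its place gives a number 88 percentage points lower from compound 2 to compound 3 (beyond the scatter) and removes the measured inhibition. The earlier pair showed only what the carboxy adds, whereas this step shows that the carboxy does not sustain inhibition without the hydroxy. No measurement available here explains this loss. On these data alone, whether a methoxy or an amine at this place would preserve inhibition remains open, as does whether removing the hydroxy has the same effect without the carboxy.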